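Changing the aryl group on the shared core

The compounds below may be only part of what the source reports. "The series", "measured", "known", "first", "only" and "open" are said of these compounds alone.

Three compounds share one core and differ only in the aryl group on a saturated chain carbon bound to a nitrogen on an aromatic ring. Compound 1 `OC[C@H]1O[C@@H](n2cnc3c(NCc4cccc(Br)c4)ncnc32)[C@H](O)[C@@H]1O` carries a 3-bromophenyl there; in a functional assay on G-361 cells (Homo sapiens) for antiproliferative activity, with a stated time of 72 h (on this read-out lower numbers stand for stronger inhibition and higher numbers for weaker inhibition), compound 1 gives > 166000 nM, which is a limit of the assay and not a number. Compound 2 `OC[C@H]1O[C@@H](n2cnc3c(NCc4c(F)ccc(F)c4F)ncnc32)[C@H](O)[C@@H]1O` carries a 2,3,6-trifluorophenyl, and in this assay compound 2 gives > 166000 nM, again a limit. Compound 3 `OC[C@H]1O[C@@H](n2cnc3c(NCc4ccccc4OC(F)F)ncnc32)[C@H](O)[C@@H]1O` carries a 2-(difluoromethoxy)phenyl; in this assay compound 3 gives > 166000 nM, a limit as well. Compound 3 thus stands where every value shown stands: the limit of > 166000 nM in this assay, at which 3 of the 3 values shown sit. The steps a step that the two limits leave unreadable from compound 1 to compound 2, a step that the two limits leave unreadable from compound 1 to compound 3 and a step that the two limits leave unreadable from compound 2 to compound 3 therefore have no readable size. Compound 4 `OC[C@H]1O[C@@H](n2cnc3c(NCc4ccc(C(F)(F)F)cc4)ncnc32)[C@H](O)[C@@H]1O` differs from compound 3 in one place: 4-(trifluoromethyl)phenyl in place of 2-(difluoromethoxy)phenyl on a saturated chain carbon bound to a nitrogen on an aromatic ring. Since each aryl variant so far sits at the limit, no step beyond the scatter is expected in this assay, and the estimated step that the limit leaves unreadable from compound 3 to compound 4 is expected to be small. Compound 4 is therefore expected to give about 200000 nM in this assay, within 80000 nM to 600000 nM.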

Compound 4, half-maximal inhibitory concentration: > 166000 nM
Compound 4: only a limit was reported (the forecaster's own chance of this, stated with the estimate: 85%); the middle value lies beyond the limit too.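

In this assay compound 4 gives > 166000 nM, a limit of the assay and not a number. Its steps from compound 1, compound 2 and compound 3 cannot be read, as all four compounds stand together: the limit of > 166000 nM in this assay, at which 4 of the 4 values shown sit.

The compounds shown leave open whether changing the aryl group on the shared core alters antiproliferative activity at all.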